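A few compounds are considered here, and "the series" means these few. Any claim that something is new, unique, unknown or untested is made for them only; others in the source may bear on it.

Compound 1 `CC(C#CCn1ccnc1)N1CCCC1=O` gives in a functional assay on the whole organism for antagonist activity, with Mus musculus as the target (on this read-out lower numbers stand for an effect already at smaller amounts and higher numbers for an effect only at larger amounts of compound), a value of 3.7 mg/kg. For compound 2 `CC(C#CCN(C)C)N1CCCC1=O` this assay reports only a limit, > 100 mg/kg. The step of an at least 27-fold higher number from compound 1 to compound 2 (1.43 log units; beyond the scatter) is thus large, and it goes with the change (dimethylamino in place of 1H-imidazol-1-yl on a saturated chain carbon bound to a triple-bonded carbon). The number at which compound 2 stops is the one given in the limit of > 100 mg/kg in this assay, at which 1 of the 3 values shown sits. Compound 3 `CC1CCC(=O)N1CC#CCn1ccnc1` has the same atoms as compound 1 joined differently; how the two cores differ is not broken down here. In this assay compound 3 gives 1.1 mg/kg, the lowest number of the two measured ones, and the gap to compound 1 lies beyond the scatter. Compound 4 `CC1CCC(=O)N1CC#CCN(C)C` stands to compound 3 as compound 2 stands to compound 1, with the change dimethylamino in place of 1H-imidazol-1-yl on a saturated chain carbon bound to a triple-bonded carbon made at the same place. Because the step of an at least 27-fold higher number from compound 1 to compound 2 (1.43 log units; beyond the scatter) was large, the step from compound 3 to compound 4 is expected to be large as well, about a 55-fold higher number from compound 3 to compound 4 (1.74 log units; beyond the scatter). Compound 4 is therefore estimated to give 60 mg/kg in this assay, likely between 15 mg/kg and 200 mg/kg, and may well reach only a limit.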

Compound 4, dose for half-maximal effect: > 100 mg/kg
Compound 4 was reported as a limit; the forecaster's own chance of this, stated with the estimate: 55%; middle value at least 1.6-fold (0.22 log units) from the limit.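

On the core of compound 3, dimethylamino in place of 1H-imidazol-1-yl goes with an at least 90-fold higher number from compound 3 to compound 4 (1.95 log units; beyond the scatter) in this assay. The change thus points the same way and is large on both cores shown, which is what these two pairs can say about carrying it from one core to the other: the same change on two cores in this assay, an at least 27-fold higher number (1.43 log units; beyond the scatter) from compound 1 to compound 2 and an at least 90-fold higher number (1.95 log units; beyond the scatter) from compound 3 to compound 4; the limit leaves it open whether they differ. They do not show the true size of either step or that the core alters the effect of the change, since the numbers for compound 2 and compound 4 are both limits of the assay and not measured end points: the limit of > 100 mg/kg in this assay, at which 2 of the 4 values shown sit.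

The two cores shown leave open whether the same change would behave alike on a third core. As far as these compounds go, it also remains open whether a pyrazole, a triazole or a longer chain bearing 1H-imidazol-1-yl would keep the low numbers seen with compound 1 and compound 3, or whether a cyclic amine such as pyrrolidine would fall with dimethylamino.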